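This account rests on a few compounds, and the source may have more. Where it says the series, first, only, none or still open, it means among the compounds named here.

- Compound 1 `COc1ccc(/C=C/C(=O)C(=Cc2cc(OC)c(OC)c(OC)c2)C(=O)/C=C/c2ccc(OC)c(OC)c2)cc1OC`: 230 nM
- Compound 2 `COc1ccc(/C=C/C(=O)C(=Cc2cccc(F)c2)C(=O)/C=C/c2ccc(OC)c(OC)c2)cc1OC`: 580 nM

In a functional assay on A549 cells (Homo sapiens) for inhibition, read by sulforhodamine B assay, with a stated time of 48 h (on this read-out higher numbers stand for weaker inhibition of growth and lower numbers for stronger inhibition of growth), compound 2 gives 580 nM, the higher of the two numbers, so it is the weaker growth inhibitor of this pair. Compound 3 `COc1ccc(/C=C/C(=O)C(=Cc2ccc(F)cc2)C(=O)/C=C/c2ccc(OC)c(OC)c2)cc1OC` differs from it in one place, on a double-bonded chain carbon: 4-fluorophenyl in place of 3-fluorophenyl on a double-bonded chain carbon bound to a double-bonded chain carbon. Within the data shown here, the only measured step at this place is a 2.5-fold higher number from compound 1 to compound 2 (0.40 log units; beyond the scatter). That step swapped a whole substituted phenyl group, whereas this change keeps the same atoms, so only a smaller shift seems likely. The expected change is a 1.2-fold lower number from compound 2 to compound 3 (0.06 log units; within the scatter), with no step beyond the scatter anticipated. For compound 3 the estimate is 500 nM, with an expected range of 220 nM to 1100 nM.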

Compound 3, concentration for 50% growth inhibition: 550 nM
Beside the measured number, compound 3's estimate is 1.1-fold (0.04 log units) below it; the range from low to high includes it.
By their numbers in this assay, from the lowest: compound 1; then compounds 3 and 2 (each within the scatter of the next).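

In this assay, the swap of 3-fluorophenyl for 4-fluorophenyl gives a 1.1-fold lower number from compound 2 to compound 3 (0.02 log units; within the scatter), so this position does not tell these two fluorophenyl groups apart. The second fluorophenyl group also sits on the same side of 3,4,5-trimethoxyphenyl as the first, with a 2.4-fold higher number from compound 1 to compound 3 (0.38 log units; beyond the scatter). No measurement shown here explains this result.

Still open, from the compounds shown here alone, is how groups other than fluorine would behave on this phenyl ring, such as an amine or a carboxylic acid, and whether either could match or pass compound 1.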